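The source may hold more compounds than are shown below. What is called first, only, known or untested is meant among the compounds shown, and "the series" means these compounds.

Measured compounds:
compound 1, `Cc1nc2sc(Nc3ccccc3)nc2c(=O)[nH]1`, which in an assay on CHO cells for displacement of a labelled ligand from adenosine receptor A3 (Homo sapiens), read by scintillation counting, with a stated time of 120 min, tested at 1 uM (on this read-out lower numbers stand for less inhibition and higher numbers for more inhibition at the one concentration tested (going by the name of the read-out)), gives 45%
compound 2, `Cc1ccc(Nc2nc3c(=O)[nH]c(C)nc3s2)cc1`, which in this assay gives 47%
compound 3, `CCOc1nc(C)nc2sc(-c3ccccc3)nc12`, which in this assay gives 6%

Compounds 1 and 2 share one core and differ only by methyl in place of hydrogen on an aromatic carbon. This change made a step of a number 2 percentage points higher from compound 1 to compound 2 (within the scatter), so the two numbers cannot be told apart. Compound 3 rests on a second core; the difference between the two cores is not broken down here. Its number is the lowest of the three, and the distance to compounds 1 and 2 lies beyond the scatter in both cases.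

Compound 4, `CCOc1nc(C)nc2sc(-c3ccc(C)cc3)nc12`, has not yet been measured. Going by the values given here, it differs from compound 3 by methyl in place of hydrogen on an aromatic carbon, which is the same change as the one from compound 1 to compound 2, at a place described in the same words. Because the earlier step of a number 2 percentage points higher from compound 1 to compound 2 (within the scatter) stayed within the scatter, the step of a number 2 percentage points higher from compound 3 to compound 4 (within the scatter) is expected to be small as well. Compound 4 is therefore estimated at 8% in this assay, most likely between -5% and 22%.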

Compound 4, a percentage reported as inhibition, at one concentration (the size of the read-out at that concentration, not a potency): 5%
Beside the measured number, compound 4's estimate is 3 percentage points above it; measured number inside the range.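

In this assay, methyl in place of hydrogen on an aromatic carbon made a step of a number 1 percentage points lower from compound 3 to compound 4 (within the scatter), and setting this beside the earlier case shows how the change behaves on the two cores: the same change on two cores in this assay, a number 2 percentage points higher (within the scatter) from compound 1 to compound 2 and a number 1 percentage points lower (within the scatter) from compound 3 to compound 4, 3 percentage points apart, within the scatter of two such steps. Within these two pairs, then, the change carried over from one core to the other in the sense that it left the number unmoved on both, whether the parent stood at the higher level of compound 1 or the low level of compound 3. This does not show that methyl is without effect on these cores in general, as it rests on two pairs read at one concentration, which gives no potency, and compound 3 at 6% leaves little room for a further fall.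

The compounds shown leave open whether a chlorine, a methoxy group, a longer chain or a carboxylic acid on the same ring would behave as methyl does. They also leave open which part of the difference between the two cores goes with the gap in their numbers.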